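The compounds below may be only part of what the source reports. "The series", "measured", "known", "first", "only" and "open" are said of these compounds alone.

Measured so far in an assay on HEK293 cells for displacement of a labelled ligand from prostaglandin D2 receptor 2 (Homo sapiens); on this read-out higher numbers stand for weaker inhibition and lower numbers for stronger inhibition:

Compound 1, `COc1ccc(CSc2nc3ccccc3n2CC(=O)O)cc1`: 210 nM
Compound 2, `O=C(O)Cn1c(SCc2ccc(Br)cc2)nc2ccccc21`: 220 nM
Compound 3, `COC(=O)c1ccc(OC)c(CSc2nc3ccccc3n2CC(=O)O)c1`: 29 nM

Compound 1 and compound 2 differ in one place: bromo in place of methoxy on an aromatic carbon. This gave a 1.0-fold higher number from compound 1 to compound 2 (0.02 log units; within the scatter), so the two values show no separation.

Compound 3 carries the lowest number of the three; against compound 1 the gap is beyond the scatter, and against compound 2 likewise. How the core of compound 3 differs from the core of compound 1 is not broken down here.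

Compound 4, `COC(=O)c1ccc(Br)c(CSc2nc3ccccc3n2CC(=O)O)c1`, is not yet measured in this assay. It relates to compound 3 by bromo in place of methoxy on an aromatic carbon. This is the same kind of change as that from compound 1 to compound 2, not the same: in compound 1 the place is para to a large group, while in compound 3 it is ortho to a large group and para to a methoxycarbonyl group.

Since the earlier step, a 1.0-fold higher number from compound 1 to compound 2 (0.02 log units; within the scatter), stayed within the scatter, the expected step from compound 3 to compound 4 is a 1.1-fold higher number from compound 3 to compound 4 (0.04 log units; within the scatter). Compound 4 is therefore estimated at 32 nM in this assay, expected to fall between 12 nM and 85 nM.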

Compound 4, half-maximal inhibitory concentration: 45 nM
Compound 4: the middle estimate sits 1.4-fold (0.15 log units) below what was measured; low and high end bracket the measured number.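

In this assay, bromo in place of methoxy on an aromatic carbon gave a 1.6-fold higher number from compound 3 to compound 4 (0.19 log units; within the scatter), so on the core of compound 3 the swap separates the two values no more than it did on the core of compound 1. The two steps do not differ from each other: the same change on two cores in this assay, a 1.0-fold higher number (0.02 log units; within the scatter) from compound 1 to compound 2 and a 1.6-fold higher number (0.19 log units; within the scatter) from compound 3 to compound 4, 1.5-fold (0.17 log units) apart, within the scatter of two such steps. This shows that the swap carried over between these two cores without a step beyond the scatter, in one case at a place ortho to a large group and para to a methoxycarbonyl group; it does not show that the swap would behave the same way on any other core, and two pairs are too few to support a general rule.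

Still open, on these data alone, is how other groups at the same place, such as chloro, an amine or a longer alkoxy chain, would compare with bromo and methoxy. Also open, as far as these compounds go, is what replacing the methoxycarbonyl group with a nitrile or an amide would do on this core.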